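The compounds below may be only part of what the source reports. "The series", "measured", "known", "first", "only" and "open" are said of these compounds alone.

Of the compounds shown here, three have been measured in a functional assay on the whole organism (blood, strain ICR) with Mus musculus as the target, in the glucose tolerance test, with a stated time of 30 min; a higher number here means that more compound is needed for the effect, a lower number that less compound is needed. Compound 1, `NC(=O)CC1CCN(c2nc(-c3cc(F)c(Cl)cc3F)nc3c2CS(=O)(=O)C3)CC1`, gives 0.1 mg/kg. Compound 2, `O=S1(=O)Cc2nc(-c3cc(F)c(Cl)cc3F)nc(N3CCC(O)CC3)c2C1`, gives 1 mg/kg. Compound 3, `NC(=O)CN1CCN(c2nc(-c3cc(F)c(Cl)cc3F)nc3c2CS(=O)(=O)C3)CC1`, gives 3 mg/kg, which is the highest number of the three: the step of a 3.0-fold higher number from compound 2 to compound 3 (0.48 log units; beyond the scatter) separates it from its nearest neighbour, and the step of a 30-fold higher number from compound 1 to compound 3 (1.48 log units; beyond the scatter) separates it from the furthest.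

Compound 4, `O=S1(=O)Cc2nc(-c3cc(F)c(Cl)cc3F)nc(N3CCC(CCO)CC3)c2C1`, is the next member and has not yet been measured. Its change from compound 3 is 4-(2-hydroxyethyl)piperidin-1-yl in place of 4-(carbamoylmethyl)piperazin-1-yl on an aromatic carbon. Going by the values given here, two measured steps bear on this change. The move from a 4-hydroxypiperidin-1-yl to the 4-(carbamoylmethyl)piperazin-1-yl group gave a 3.0-fold higher number from compound 2 to compound 3 (0.48 log units; beyond the scatter), and the move from a 4-(carbamoylmethyl)piperidin-1-yl to the same piperazinyl group gave a 30-fold higher number from compound 1 to compound 3 (1.48 log units; beyond the scatter). Compound 4 returns to a piperidin-1-yl ring and carries a hydroxy group on a short chain, so the change runs back toward compounds 2 and 1. The expectation is therefore a lower number in this assay for compound 4 than for compound 3, and the expected step is a 10-fold lower number from compound 3 to compound 4 (1.00 log units; beyond the scatter). The estimate for compound 4 in this assay is 0.3 mg/kg, within a range from 0.1 mg/kg to 1 mg/kg.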

Compound 4, minimum effective dose in the Mus musculus assay: 1 mg/kg
Compound 4: the middle estimate sits 3.3-fold (0.52 log units) below what was measured; the range from low to high includes it.
By their numbers in the Mus musculus assay, from the lowest: compound 1; then compounds 2 and 4 (each within the scatter of the next); then compound 3.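

In the Mus musculus assay, the 4-(2-hydroxyethyl)piperidin-1-yl group in place of the 4-(carbamoylmethyl)piperazin-1-yl group gives a 3.0-fold lower number from compound 3 to compound 4 (0.48 log units; beyond the scatter), 2-hydroxyethyl in place of hydroxy on the saturated ring carbon gives no change at the digits printed from compound 2 to compound 4 (within the scatter), and hydroxymethyl in place of carbamoyl on the same chain gives a 10-fold higher number from compound 1 to compound 4 (1.00 log units; beyond the scatter), so with the piperidine ring kept, the carbamoyl end of the chain separates compound 1 from compound 4, while the two alcohols cannot be told apart. In a physicochemical assay for solubility, with a stated time of 20 h, at pH 6.8 (a lower number here means a less soluble compound, a higher number a more soluble compound), compound 3 gives > 100000 nM, which is a limit of the assay and not a number: the limit of > 100000 nM in the physicochemical assay, at which 1 of the 2 values shown sits. In the physicochemical assay compound 4 gives 23000 nM, and the change reads as an at least 4.3-fold lower number from compound 3 to compound 4 (0.63 log units; beyond the scatter).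

The compounds shown leave open whether the carbamoyl result depends on the carbonyl or on the amide hydrogen, which a carboxylic acid or a nitrile on the same chain could address. They also leave open whether the ring or its substituent sets the position of compound 3, which a 4-(2-hydroxyethyl)piperazin-1-yl group would separate.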